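The source may hold more compounds than are shown below. What is called first, only, known or untested is meant among the compounds shown, and "the series" means these compounds.

Among the measured compounds shown here, compound 2 `NC[C@H]1CC[C@H](CN(C[C@H]2Cc3ccccc3CN2)[C@H]2CCCc3cccnc32)CC1` gives 340 nM in a functional assay on CCRF-CEM cells for antagonist activity at C-X-C chemokine receptor type 4 (Homo sapiens), read by calcium flux, with stated times of 25 min and 90 s (a higher number here means a weaker inhibitor, a lower number a stronger inhibitor), the highest of the two numbers measured so far. For the measured compounds named here, the other measured compound, compound 1 `C/C(CN)=C(/F)CN(C[C@H]1Cc2ccccc2CN1)[C@H]1CCCc2cccnc21`, gives 44 nM, and the single step that joins them, a 7.7-fold higher number from compound 1 to compound 2 (0.89 log units; beyond the scatter), lies beyond the scatter. Compound 3 `C/C(=C/CN)CN(C[C@H]1Cc2ccccc2CN1)[C@H]1CCCc2cccnc21` undoes part of that step: a group of 5 heavy atoms (4 carbon, 1 nitrogen; no ring) in place of a group of 8 heavy atoms (7 carbon, 1 nitrogen; one six-membered non-aromatic ring of carbon only), on a saturated chain carbon bound to an amine nitrogen. Because compound 1 gives 44 nM with an open chain carrying a double bond on the same saturated chain carbon bound to an amine nitrogen, the expected change is a drop in the number. The expected step is a 4.3-fold lower number from compound 2 to compound 3 (0.63 log units; beyond the scatter). For compound 3 the estimate is 80 nM, with a range from 25 nM to 250 nM.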

Compound 3, half-maximal inhibitory concentration: 28 nM
Beside the measured number, compound 3's estimate is 2.9-fold (0.46 log units) above it; low and high end bracket the measured number.
By their numbers in this assay, from the lowest: compounds 3 and 1 (each within the scatter of the next); then compound 2.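

Swapping the 4-(aminomethyl)cyclohexyl group for the open chain on the saturated chain carbon bound to an amine nitrogen gives a 12-fold lower number from compound 2 to compound 3 (1.08 log units; beyond the scatter), so in this assay this position does not need the ring. The two open chains, one with fluorine and one without, cannot be told apart: a 1.6-fold lower number from compound 1 to compound 3 (0.20 log units; within the scatter). No measurement offered here explains the gain from the ring to the open chain. Going by these compounds, whether the double bond matters remains open, and a saturated 4-aminobutyl chain would test that. So does the role of the terminal amine, which a hydroxyl in its place would probe.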